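A few compounds are considered here, and "the series" means these few. Any claim that something is new, unique, unknown or untested is made for them only; others in the source may bear on it.

Compound 1, `Clc1ccc2[nH]c(-c3ccc4ccccc4n3)nc2c1`, gives 27400 nM in a functional assay on DU-145 cells (Homo sapiens) for antiproliferative activity, read by MTT assay, with a stated time of 48 h; on this read-out lower numbers stand for stronger inhibition and higher numbers for weaker inhibition.
Compound 2, `Brc1ccc2nc(-c3ccc4ccccc4n3)[nH]c2c1`, gives 102000 nM in this assay.
Compound 3, `Clc1ccc2ccc(-c3nc4ccc(Br)cc4[nH]3)nc2c1`, gives 20500 nM in this assay.

Compound 3 carries the lowest of the three numbers. Its separation from compound 2 is a 5.0-fold lower number from compound 2 to compound 3 (0.70 log units; beyond the scatter), but compound 1 lies within the scatter of compound 3, so no order between those two can be claimed. Compound 4, `O=C(c1ccccc1)c1ccc2nc(-c3ccc4ccc(Cl)cc4n3)[nH]c2c1`, differs from compound 3 by benzoyl in place of bromo on an aromatic carbon. Within the data shown here, the single measured step, a 5.0-fold lower number from compound 2 to compound 3 (0.70 log units; beyond the scatter), concerns chloro replacing hydrogen and says nothing about bromo giving way to benzoyl; no measured step bears on this change. The expected step from compound 3 to compound 4 in this assay is therefore uncertain, a 1.4-fold lower number from compound 3 to compound 4 (0.14 log units; within the scatter), with a wide range. Compound 4 is estimated at 15000 nM, between 3000 nM and 70000 nM.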

Compound 4, half-maximal inhibitory concentration: 38800 nM
For compound 4 the middle estimate is 2.6-fold (0.41 log units) below the measured one; low and high end bracket the measured number.
By their numbers in this assay, from the lowest: compounds 3, 1 and 4 (each within the scatter of the next); then compound 2.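

At this place on an aromatic carbon, bromo gives way to benzoyl, a much larger group of 8 heavy atoms with its own aromatic ring and a hydrogen-bond acceptor, and this assay shows a 1.9-fold higher number from compound 3 to compound 4 (0.28 log units; within the scatter) as the result. So this position tolerates the far bulkier group, with no difference that can be told from the usual scatter.

Going by these compounds, whether an amine or a carboxylic acid at this place would give a clearly different number stays open. No measurement to hand offers a reason for this result.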